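The source may hold more compounds than are shown below. What is called first, only, known or untested is meant among the compounds shown, and "the series" means these compounds.

Measured in a functional assay on BaF3 cells (Mus musculus) for antiproliferative activity; on this read-out higher numbers stand for an effect only at larger amounts of compound and lower numbers for an effect already at smaller amounts:
- compound 1 `CCN1CCN(Cc2ccc(NC(=O)c3ccc(C)c(C#Cc4cccnc4)c3)cc2C(F)(F)F)CC1`: 1590 nM
- compound 2 `CCN1CCN(Cc2ccc(NC(=O)c3ccc(C)c(C#Cc4cncnc4)c3)cc2C(F)(F)F)CC1`: 2190 nM
- compound 3 `CCN1CCN(Cc2ccc(NC(=O)c3ccc(C)c(C#Cc4cnccn4)c3)cc2C(F)(F)F)CC1`: 2490 nM

Compound 3, at 2490 nM, stands within the scatter of both other compounds, as shown by a 1.6-fold higher number from compound 1 to compound 3 (0.19 log units; within the scatter) and a 1.1-fold higher number from compound 2 to compound 3 (0.06 log units; within the scatter). Compound 4 `CCN1CCN(Cc2ccc(NC(=O)c3ccc(C)c(C#Cc4cnc(N)cn4)c3)cc2C(F)(F)F)CC1` keeps the core of compound 3 and turns pyrazin-2-yl into 5-aminopyrazin-2-yl: amino in place of hydrogen on an aromatic carbon.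

The nearest evidence comes from the changes of the aromatic ring on the triple bond, namely a 1.4-fold higher number from compound 1 to compound 2 (0.14 log units; within the scatter), together with the two steps above. All three are small and within the scatter. None of them adds an amino group, however, so they bear on this change only indirectly. No step beyond the scatter is therefore expected in this assay, although the untested group calls for a wide range, and a lower number is judged somewhat more likely than a higher one. The expected step is a 1.8-fold lower number from compound 3 to compound 4 (0.25 log units; within the scatter). Compound 4 is estimated at 1400 nM, with an expected range from 350 nM to 3500 nM.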

Compound 4, half-maximal effective concentration: 860 nM
For compound 4 the middle estimate is 1.6-fold (0.21 log units) above the measured one; the range from low to high includes it.
By their numbers in this assay, from the lowest: compounds 4, 1, 2 and 3 (each within the scatter of the next, the first and the last beyond it).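

In this assay the earlier changes of the ring on the triple bond all stayed within the scatter, whereas amino in place of hydrogen on this aromatic carbon, para to a large group, gives a 2.9-fold lower number from compound 3 to compound 4 (0.46 log units; beyond the scatter). The 5-aminopyrazin-2-yl group also separates from pyrimidin-5-yl, with a 2.5-fold lower number from compound 2 to compound 4 (0.41 log units; beyond the scatter), but not from pyridin-3-yl, with a 1.8-fold lower number from compound 1 to compound 4 (0.27 log units; within the scatter), so the step beyond the scatter holds against two of the three earlier rings only. Nothing measured here accounts for the step.

The compounds shown carry the amino group on the pyrazin-2-yl ring alone, and whether it would give a similar step on the pyridin-3-yl ring of compound 1 stays open. Equally open, on these data alone, is how a methylamino, dimethylamino or methoxy group on the same carbon would read in this assay.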